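A few compounds are considered here, and "the series" means these few. Any claim that something is new, unique, unknown or untested is made for them only; others in the source may bear on it.

Series notes on the shared core. In a functional assay on CHO-K1 cells for antagonist activity at adenosine receptor A1 (Homo sapiens), read by a beta-galactosidase reporter and cAMP accumulation, with stated times of 15 min and 6 h (on this read-out higher numbers stand for weaker inhibition and lower numbers for stronger inhibition), compound 3 `Nc1nc(-c2ccccc2)nc2sc(Cc3ccccc3)cc12` gives 151 nM, the lowest of the three numbers recorded. Compound 1 `Cc1nc(-c2nc(N)c3cc(Cc4ccccc4)sc3n2)cs1` gives 263 nM; the step of a 1.7-fold lower number from compound 1 to compound 3 (0.24 log units; within the scatter) stays within the scatter, so compound 3 and compound 1 cannot be ordered. Compound 2 `Cn1cnc(-c2nc(N)c3cc(Cc4ccccc4)sc3n2)c1` gives 2330 nM; the step of a 15-fold lower number from compound 2 to compound 3 (1.19 log units; beyond the scatter) is the largest in the set, and an 8.9-fold higher number from compound 1 to compound 2 (0.95 log units; beyond the scatter) runs the same way. Compound 4 `COc1cccc(-c2nc(N)c3cc(Cc4ccccc4)sc3n2)c1` differs from compound 3 by methoxy in place of hydrogen on an aromatic carbon of a six-membered aromatic ring of carbon only, meta to a large group. Every measured step exchanges the whole aromatic group; none alters a substituent on the phenyl, so none bears directly on this change. A step in this assay no larger than the scatter is therefore expected, a 1.0-fold lower number from compound 3 to compound 4 (0.00 log units; within the scatter). For compound 4 the estimate is 150 nM, with a range of 50 nM to 500 nM.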

Compound 4, inhibition constant: 266 nM
Estimate against measurement, compound 4: 1.8-fold (0.25 log units) below; low and high end bracket the measured number.
By their numbers in this assay, from the lowest: compounds 3, 1 and 4 (each within the scatter of the next); then compound 2.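

Methoxy on the phenyl, meta to a large group, gives the first measured step that alters a substituent rather than exchanging the whole aromatic group, and it stays within the scatter (a 1.8-fold higher number from compound 3 to compound 4 (0.25 log units; within the scatter)). The 3-methoxyphenyl group also cannot be ordered against 2-methyl-1,3-thiazol-4-yl (a 1.0-fold higher number from compound 1 to compound 4 (0.00 log units; within the scatter)), while the gap to 1-methyl-1H-imidazol-4-yl persists beyond the scatter (an 8.8-fold lower number from compound 2 to compound 4 (0.94 log units; beyond the scatter)). No measured evidence explains these steps.

Still open, from the compounds shown here alone, is whether an amine or a carboxylic acid at this place would move the number beyond the scatter. Also open, going by these compounds, is whether methoxy elsewhere on the phenyl would behave alike.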